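From an Amino Alcohol Chain to a Pyrrolidine Ring

A few compounds are considered here, and "the series" means these few. Any claim that something is new, unique, unknown or untested is made for them only; others in the source may bear on it.

Of the compounds shown here, three sharing one core have been tested in a functional assay on MDA-MB-435 cells (Homo sapiens) for inhibition; on this read-out higher numbers stand for weaker inhibition and lower numbers for stronger inhibition. Compound 1 `COc1cc[nH]c1/C=C1\C(=O)Nc2ccc(F)c(C#C[C@@H](C)O)c21` gives 110 nM. Compound 2 `COc1cc[nH]c1/C=C1\C(=O)Nc2ccc(F)c(C#C[C@H](N)CO)c21` gives 320 nM, and compound 3 `COc1cc[nH]c1/C=C1\C(=O)Nc2ccc(F)c(C#C[C@@H](N)CO)c21` gives 300 nM. Compound 2 therefore stands at the highest number of the three: its nearest neighbour is compound 3, with a 1.1-fold lower number from compound 2 to compound 3 (0.03 log units; within the scatter), and its furthest is compound 1, with a 2.9-fold higher number from compound 1 to compound 2 (0.46 log units; beyond the scatter). The closeness of compounds 2 and 3 fits (the fact that compounds 2 and 3 differ only in the configuration as drawn).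

Compound 4 `COc1cc[nH]c1/C=C1\C(=O)Nc2ccc(F)c(C#C[C@@H]3CCCN3)c21` has not yet been measured. Relative to compound 2 the change is pyrrolidin-2-yl in place of 1-amino-2-hydroxyethyl on a triple-bonded carbon. The measured steps bear on it in two ways. Replacing the group on the triple-bonded carbon moved the number modestly, as in a 2.9-fold higher number from compound 1 to compound 2 (0.46 log units; beyond the scatter) and a 2.7-fold higher number from compound 1 to compound 3 (0.44 log units; beyond the scatter), while the configurational swap in a 1.1-fold lower number from compound 2 to compound 3 (0.03 log units; within the scatter) stayed within the scatter. The incoming pyrrolidin-2-yl keeps a nitrogen but holds it within a five-membered ring and carries no hydroxyl, a change of a size comparable to those already seen, so a modest shift in either direction seems plausible rather than a large one. Compound 4 is therefore expected near 200 nM, within a range from 70 nM to 600 nM, which corresponds to an expected step of a 1.6-fold lower number from compound 2 to compound 4 (0.20 log units; within the scatter).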

Compound 4, half-maximal inhibitory concentration: 31 nM
Compound 4: middle estimate off by 6.5-fold (0.81 log units), on the high side, outside the stated range (below it).
By their numbers in this assay, from the lowest: compound 4; then compound 1; then compounds 3 and 2 (each within the scatter of the next).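

In this assay, within the data shown here, the position on the triple-bonded carbon turns out to be far more sensitive than the earlier compounds suggested: pyrrolidin-2-yl in place of 1-amino-2-hydroxyethyl gives a 10-fold lower number from compound 2 to compound 4 (1.01 log units; beyond the scatter) and, starting from the other configuration of the chain, a 9.7-fold lower number from compound 3 to compound 4 (0.99 log units; beyond the scatter), whereas the earlier swap of configuration had stayed within the scatter. The earlier replacements had only raised the number, so a change at this position can also lower it, and the ring even outdoes the small 1-hydroxyethyl group, with a 3.5-fold lower number from compound 1 to compound 4 (0.55 log units; beyond the scatter), which makes compound 4 the strongest of the four. The change also does several things at once, closing a ring around the nitrogen and removing the hydroxyl, so the steps cannot say which of these matters.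

The compounds shown leave open whether an open-chain 1-aminoethyl group, which has the nitrogen but no ring, would match the pyrrolidin-2-yl group, and whether a piperidin-2-yl ring or the opposite configuration of the pyrrolidin-2-yl group would keep the low number. Nothing measured here accounts for the size of this step.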